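A few compounds are considered here, and "the series" means these few. Any claim that something is new, unique, unknown or untested is made for them only; others in the source may bear on it.

Compound 1 `CC(=O)Nc1nc2ccc(NC(=O)c3c(Cl)cccc3Cl)cc2s1` gives 0.6 ug/mL in a functional assay on WI-38 VA13 cells (Homo sapiens) for cytotoxicity; a higher number here means that more compound is needed for the effect, a lower number that less compound is needed.
Compound 2 `O=C(O)CCC(=O)Nc1nc2ccc(NC(=O)c3c(Cl)cccc3Cl)cc2s1` reaches only a limit of this assay, > 6.6 ug/mL.
Compound 3 `CC(C)OC(=O)Nc1nc2ccc(NC(=O)c3c(Cl)cccc3Cl)cc2s1` gives 0.0026 ug/mL in this assay.

Of the two numbers that are not limits, compound 3 holds the lower one; its nearest neighbour is compound 1, and the step of a 230-fold lower number from compound 1 to compound 3 (2.36 log units; beyond the scatter) separates them. The value of compound 2 is a limit (the limit of > 6.6 ug/mL in this assay, at which 1 of the 3 values shown sits), so the step of an at least 11-fold higher number from compound 1 to compound 2 (1.04 log units; beyond the scatter) and the step of an at least 2500-fold lower number from compound 2 to compound 3 (3.40 log units; beyond the scatter) are known only as bounds.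

Compound 4 `CC(C)COC(=O)Nc1nc2ccc(NC(=O)c3c(Cl)cccc3Cl)cc2s1` differs from compound 3 in one place: isobutyl in place of isopropyl on an oxygen next to a carbonyl group. Among the measured compounds shown here, none of the measured steps changes the group on that oxygen; the step of a 230-fold lower number from compound 1 to compound 3 (2.36 log units; beyond the scatter) concerns the carbonyl carbon itself and the step of an at least 11-fold higher number from compound 1 to compound 2 (1.04 log units; beyond the scatter) concerns the chain on the other carbonyl, so neither speaks directly to this exchange. For the measured compounds named here, with no measured precedent for exchanging one alkyl group for a closely related one on that oxygen, the expected step of a 1.5-fold higher number from compound 3 to compound 4 (0.19 log units; within the scatter) is small and within the scatter of this assay. Compound 4 is therefore expected to give about 0.004 ug/mL in this assay, between 0.001 ug/mL and 0.015 ug/mL.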

Compound 4, half-maximal effective concentration: 0.0035 ug/mL
Compound 4: middle estimate off by 1.1-fold (0.06 log units), on the high side; the measured number falls inside the stated range.
By their numbers in this assay, from the lowest: compounds 3 and 4 (each within the scatter of the next); then compound 1. At a limit, above all of these: compound 2.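

The only change shown at this place, isobutyl in place of isopropyl on an oxygen next to a carbonyl group, gives a 1.3-fold higher number from compound 3 to compound 4 (0.13 log units; within the scatter), so compound 3 and compound 4 cannot be told apart in this assay. Isobutoxy in place of methyl on a carbonyl carbon gives a 170-fold lower number from compound 1 to compound 4 (2.23 log units; beyond the scatter), a large step of the same kind as a 230-fold lower number from compound 1 to compound 3 (2.36 log units; beyond the scatter), so among these compounds the low number is not confined to the isopropoxy group. The step of an at least 1800-fold lower number from compound 2 to compound 4 (3.27 log units; beyond the scatter) is known only as a bound, as one of its ends is a limit and not a number: the limit of > 6.6 ug/mL in this assay, at which 1 of the 4 values shown sits.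

The compounds shown leave open whether a longer chain, a ring or a chain ending in an amine on that oxygen would keep the number as low as isopropyl and isobutyl do. They also leave open which part of the 2-carboxyethyl group in compound 2 goes with its large distance from the compounds that carry isopropoxy or isobutoxy on the carbonyl carbon.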